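Extending the Chain: Compound 3 to Compound 4

This account rests on a few compounds, and the source may have more. Where it says the series, first, only, none or still open, it means among the compounds named here.

Measured in a functional assay on A549 cells (Homo sapiens) for inhibition, with a stated time of 48 h, tested at 50 uM; a higher number here means more inhibition of growth at the concentration tested, a lower number less inhibition of growth:
- compound 1 `C=C[C@@](C)(/C=C/c1ccc(OC(=O)CC)cc1)CCC=C(C)C`: 42%
- compound 2 `C=C[C@@](C)(/C=C/c1ccc(OC(=O)CCCC)cc1)CCC=C(C)C`: 38%
- compound 3 `C=C[C@@](C)(/C=C/c1ccc(OC(=O)CCCCCCC)cc1)CCC=C(C)C`: 15%

Compound 3 has the lowest number of the three, and its gaps to compound 1 and compound 2 both lie beyond the scatter. The next compound, compound 4 `C=C[C@@](C)(/C=C/c1ccc(OC(=O)CCCCCCCCC)cc1)CCC=C(C)C`, differs from it in a single place: ethyl in place of hydrogen on a saturated chain carbon, seven bonds along the chain from a carbonyl carbon. Two measured steps on the same chain bear on this change. One ethyl addition gave a number 4 percentage points lower from compound 1 to compound 2 (within the scatter), while a propyl addition gave a number 23 percentage points lower from compound 2 to compound 3 (beyond the scatter), and together the chain changes gave a number 27 percentage points lower from compound 1 to compound 3 (beyond the scatter). All of them point downward, although one stayed within the scatter, and three compounds give a direction rather than a rule. The change here is also an ethyl addition, though at a different place along the chain, so only a small further fall in this assay is expected, none beyond the scatter. The estimated size is a number 5 percentage points lower from compound 3 to compound 4 (within the scatter) for this step. Compound 4 is expected to give about 10% as a value, with an estimated range from 0% to 22% in this measurement.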

Compound 4, percent growth inhibition at one concentration: 48%
For compound 4 the middle estimate is 38 percentage points below the measured one; the measured number lies above the stated range.
By their numbers in this assay, from the lowest: compound 3; then compounds 2, 1 and 4 (each within the scatter of the next).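

In this assay, ethyl in place of hydrogen, seven bonds along the chain from a carbonyl carbon, gave a number 33 percentage points higher from compound 3 to compound 4 (beyond the scatter), a reversal of the earlier fall rather than its continuation. The same ethyl addition therefore has no fixed effect on this chain, and where it lands matters: the same change on two cores in this assay, a number 4 percentage points lower (within the scatter) from compound 1 to compound 2 and a number 33 percentage points higher (beyond the scatter) from compound 3 to compound 4, 37 percentage points apart, beyond the scatter of two such steps Against the shorter chains, the result is a number 10 percentage points higher from compound 2 to compound 4 (within the scatter) and a number 6 percentage points higher from compound 1 to compound 4 (within the scatter), so compound 3 alone sits low and chain length gives no steady trend across these four compounds.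

On these data alone, with one value per compound, it remains open whether the low number of compound 3 is a true dip, and nothing here explains the recovery. A longer chain than that of compound 4 would show whether the number holds, falls or rises further.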